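Swapping the Cyclohexyl for a Methoxypropyl Chain

The source may hold more compounds than are shown below. What is called first, only, known or untested is meant among the compounds shown, and "the series" means these compounds.

Of the three compounds measured in an assay on isolated protein for inhibition of tyrosine-protein kinase receptor UFO (Homo sapiens), read by ELISA (on this read-out higher numbers stand for weaker inhibition and lower numbers for stronger inhibition), compound 1 `Cn1cc(-c2ccc(NC(=O)c3cn(CC4CCCCC4)cc(-c4ccc(F)cc4)c3=O)cc2)c2c(N)ncnc21` gives 2.3 nM, the highest number of the set. Compound 2 `Cn1cc(-c2ccc(NC(=O)c3cn(CC4CCOCC4)cc(-c4ccc(F)cc4)c3=O)c(F)c2)c2c(N)ncnc21` gives 0.2 nM, and compound 3 `Cn1cc(-c2cc(F)c(NC(=O)c3cn(CC4CCOCC4)cc(-c4ccc(F)cc4)c3=O)cc2F)c2c(N)ncnc21` gives 0.5 nM. Within the data shown here, the only single-point step among them, a 2.5-fold higher number from compound 2 to compound 3 (0.40 log units; beyond the scatter), concerns a fluoro substituent on the aromatic ring and has no bearing on the change considered here. Compound 1 and compound 2 differ in two places at once, so their gap cannot be assigned to either change alone.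

Compound 4 `COCCCn1cc(C(=O)Nc2ccc(-c3cn(C)c4ncnc(N)c34)cc2)c(=O)c(-c2ccc(F)cc2)c1` differs from compound 1 by 2-methoxyethyl in place of cyclohexyl on a saturated chain carbon bound to an aromatic nitrogen. Among the measured compounds shown here, no measured step in this assay touches this position in isolation, so the expectation rests on the absence of evidence for a large effect: the two values of compound 1 and compound 2 hint that an oxygen-containing group at this position need not cost potency, but nothing more can be read from them. The author therefore expects a step from compound 1 to compound 4 that stays near the scatter, a 1.1-fold higher number from compound 1 to compound 4 (0.04 log units; within the scatter), with no firm direction. Compound 4 is estimated at 2.5 nM, within a range from 0.8 nM to 8 nM.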

Compound 4, half-maximal inhibitory concentration: > 10 nM
Compound 4 gave a limit, no number (the forecaster's own chance of this, stated with the estimate: 2%); middle value at least 4.0-fold (0.60 log units) from the limit.
By their numbers in this assay, from the lowest: compound 2; then compound 3; then compound 1. At a limit, above all of these: compound 4.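

In this assay compound 4 gives > 10 nM, which is a limit of the assay and not a number. Among these compounds, the step to it, an at least 4.3-fold higher number from compound 1 to compound 4 (0.63 log units; beyond the scatter), is the first reading of this position on its own, and it shows that the group on a saturated chain carbon bound to an aromatic nitrogen is not a place where 2-methoxyethyl and cyclohexyl can be exchanged freely. Among the compounds shown here, the oxygen in the open chain of compound 4 therefore does not by itself keep the number as low as the all-carbon ring of compound 1 does, a point the earlier compounds could not settle, since those with a ring oxygen differ from compound 1 in a second place as well.

This one change removes the ring and brings in the oxygen together, so the compounds shown cannot tell which of the two carries the step. Going by these compounds, whether a plain butyl chain, or a chain ending in an amine, would read like compound 1 or like compound 4 remains open.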